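The compounds below may be only part of what the source reports. "The series", "measured", "known", "first", "only" and "open" are said of these compounds alone.

Three compounds share one core, a urea joined to a pyrimidine that carries an aryl amine, and differ only in the aryl group on that amine nitrogen. In a functional assay on NCI-H520 cells (Homo sapiens) for inhibition, read by MTT assay, with a stated time of 48 h, tested at 10 uM (a higher number here means more inhibition at the concentration tested (going by the name of the read-out), a lower number less inhibition), compound 1 `COc1ccc(F)cc1Nc1cc(NC(=O)Nc2c(Cl)cccc2Cl)ncn1` gives 38.1%, compound 2 `Cc1cc(F)cc(Nc2cc(NC(=O)Nc3c(Cl)cccc3Cl)ncn2)c1` gives 60.5%, and compound 3 `COc1ccc(Br)cc1Nc1cc(NC(=O)Nc2c(Cl)cccc2Cl)ncn1` gives 45%. Compound 3 stands second of the three: the gap from compound 1 a number 6.9 percentage points higher from compound 1 to compound 3 (within the scatter) stays within the scatter, while the step of a number 15.5 percentage points lower from compound 2 to compound 3 (beyond the scatter) lies beyond it, and the step of a number 22.4 percentage points higher from compound 1 to compound 2 (beyond the scatter) shows the same direction, so compound 2 is the only one set apart.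

Compound 4 `COc1ccc(Nc2cc(NC(=O)Nc3c(Cl)cccc3Cl)ncn2)cc1C` changes this same aryl group: 4-methoxy-3-methylphenyl in place of 5-bromo-2-methoxyphenyl on a nitrogen on an aromatic ring. The two steps that bear on it, a number 22.4 percentage points higher from compound 1 to compound 2 (beyond the scatter) and a number 15.5 percentage points lower from compound 2 to compound 3 (beyond the scatter), are both modest and both show that a 3-fluoro-5-methylphenyl group gave more inhibition than either methoxy-bearing aryl group. Compound 4 keeps a methoxy group but places it as 4-methoxy-3-methylphenyl, with a methyl as in compound 2; the data do not tell which of these features matters. A small upward step at most is expected, likely inside the scatter. Compound 4 is therefore expected to give 48%, with a range from 30% to 66%. The expected step is a number 3 percentage points higher from compound 3 to compound 4 (within the scatter).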

Compound 4, a percentage reported as inhibition, at one concentration (the size of the read-out at that concentration, not a potency): 29.1%
The estimate for compound 4 lay 18.9 percentage points above the measured number, and the stated range ends above it.
By their numbers in this assay, from the lowest: compounds 4, 1 and 3 (each within the scatter of the next, the first and the last beyond it); then compound 2.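

At this position on the amine nitrogen, a methyl on the aryl ring does not by itself go with the higher inhibition of compound 2: compound 4 carries a methyl too, yet the step of a number 31.4 percentage points lower from compound 2 to compound 4 (beyond the scatter) is the largest seen in this set. Replacing 5-bromo-2-methoxyphenyl with 4-methoxy-3-methylphenyl, two groups with the same heavy-atom count that each keep a methoxy, still gives the step of a number 15.9 percentage points lower from compound 3 to compound 4 (beyond the scatter) in this assay, which shows that the result depends on more than the size of the group by that count. The step of a number 9 percentage points lower from compound 1 to compound 4 (within the scatter) leaves compound 1 and compound 4 indistinguishable, and nothing measured here offers an explanation for any of these steps.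

Among the compounds shown here, compound 2 is the only compound without a methoxy group, and compound 1 shows that a fluoro alone does not bring the same result, but whether the missing methoxy or the particular arrangement of fluoro and methyl matters remains open. Also open, going by these compounds, is how this position would respond to an aryl group bearing an amine or a carboxylic acid in place of the fluoro of compound 2.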